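Aryl sulfonamide series: amino to nitro swap on the core

The source may hold more compounds than are shown below. What is called first, only, known or untested is meant among the compounds shown, and "the series" means these compounds.

Compound 1 `O=S(=O)(c1ccc(-c2cnc(C3CC3)o2)cc1)N1CCSc2ccccc21`: 45 nM
Compound 2 `Nc1ccc2c(c1)OCCCN2S(=O)(=O)c1ccc(-c2cnc(C3CC3)o2)cc1`: 87 nM
Compound 3 `O=[N+]([O-])c1ccc2c(c1)N(S(=O)(=O)c1ccc(-c3cnc(C4CC4)o3)cc1)CCCO2`: 133 nM

Of the compounds shown here, three have been measured in a functional assay on HCT-116 cells (Homo sapiens) for antiproliferative activity, read by MTT assay, with a stated time of 72 h; a higher number here means a weaker inhibitor, a lower number a stronger inhibitor. In this assay compound 1 gives 45 nM, compound 2 gives 87 nM and compound 3 gives 133 nM. The number for compound 2 lies within the scatter of both compound 1 and compound 3, so none of the three can be set apart on these numbers. Compound 4 `O=[N+]([O-])c1ccc2c(c1)OCCCN2S(=O)(=O)c1ccc(-c2cnc(C3CC3)o2)cc1` is not yet measured; it differs from compound 2 by nitro in place of amino on an aromatic carbon. Compound 3 also carries a nitro group, though on a differently arranged core, and its number offers the only nitro reference in the set. The step expected in this assay from compound 2 to compound 4 is a 1.3-fold higher number from compound 2 to compound 4 (0.12 log units; within the scatter), toward a higher number but not beyond the scatter. Compound 4 is estimated at 115 nM, with a range from 50 nM to 260 nM.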

Compound 4, half-maximal inhibitory concentration: 145 nM
Beside the measured number, compound 4's estimate is 1.3-fold (0.10 log units) below it; the range from low to high includes it.
By their numbers in this assay, from the lowest: compounds 1, 2, 3 and 4 (each within the scatter of the next, the first and the last beyond it).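

In this assay, among these compounds, nitro in place of amino on this aromatic carbon gives a 1.7-fold higher number from compound 2 to compound 4 (0.22 log units; within the scatter), so this is the first change that can be read in one place. At this position, the two groups cannot be set apart on these numbers. No measured data bear on why the two numbers fall as they do.

From the compounds shown here alone, whether a carboxylic acid, a methoxy group or an acetamide at this position would give a step beyond the scatter remains open. The same holds for a hydrogen in place of amino.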